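The source may hold more compounds than are shown below. What is called first, only, known or untested is meant among the compounds shown, and "the series" means these compounds.

Compound 1, with the structure `C=CCn1c(SCC(=O)c2ccccc2)nnc1-c1ccccc1`, was tested in a functional assay on the whole organism (strain albino) for inhibition, with Rattus norvegicus as the target, read by paw edema, with a stated time of 2 h, at a dose of 0.28 mmol/kg by the oral route (on this read-out lower numbers stand for less inhibition and higher numbers for more inhibition at the one dose given (going by the name of the read-out)), and gives 58%. Of the two compounds measured in this assay, compound 1 shows the higher of the two numbers, yet the gap to its neighbour is within the scatter. That neighbour, compound 2, has the structure `C=CCn1c(SC/C(=N\O)c2ccccc2)nnc1-c1ccc(OC)c(OC)c1` and in this assay gives 57%, a reading so close to that of compound 1 that the two cannot be told apart.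

Compound 3, with the structure `C=CCn1c(SCC(=O)c2ccccc2)nnc1-c1ccc(OC)cc1`, has not yet been measured in this assay. It differs from compound 1 in one place: methoxy in place of hydrogen on an aromatic carbon, on an aromatic carbon of a six-membered aromatic ring of carbon only. For the measured compounds named here, no measured pair shows this change on its own, so nothing here tells how large its effect is. The two measured values being so alike, compound 3 is expected to land near compound 1, with a step of a number 1 percentage points lower from compound 1 to compound 3 (within the scatter) that is expected to fall within the scatter. Compound 3 is therefore estimated at 57%, with a likely range from 45% to 68%.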

Compound 3, a percentage reported as inhibition, in the whole organism at one dose (the size of the read-out at that dose, not a potency): 53%
Compound 3: the middle estimate sits 4 percentage points above what was measured; the measured number falls inside the stated range.
By their numbers in this assay, from the lowest: compounds 3, 2 and 1 (each within the scatter of the next).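

In this assay, the change from phenyl to 4-methoxyphenyl can now be read on its own, as a number 5 percentage points lower from compound 1 to compound 3 (within the scatter). At this place, on an aromatic carbon para to a large group, methoxy can therefore stand in for hydrogen with no difference that can be told apart from the spread of repeated measurements at this one dose. No other measurement bears on this result.

Going by these compounds, whether a different group in this place, such as an amine, a carboxylic acid or a longer chain like butoxy, would move the reading beyond that spread remains open. Also open, on these data alone, is whether the same small step would hold at other doses, since a reading at one dose is not a potency.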